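Chloro in Place of Trifluoromethyl on a Diaryl Urea

A few compounds are considered here, and "the series" means these few. Any claim that something is new, unique, unknown or untested is made for them only; others in the source may bear on it.

Measured so far in a functional assay on EKVX cells (Homo sapiens) for inhibition, read by sulforhodamine B assay, with a stated time of 48 h; on this read-out higher numbers stand for weaker inhibition of growth and lower numbers for stronger inhibition of growth:
compound 1, `COc1cc2cc(Oc3ccc(NC(=O)Nc4cccc(C(F)(F)F)c4)cc3)c(C)nc2cc1OC`, gives 6460 nM
compound 2, `COc1cc2cc(Oc3ccc(NC(=O)Nc4ccc(Cl)c(C(F)(F)F)c4)cc3)c(C)nc2cc1OC`, gives 3750 nM

Going by the values given here, of the two numbers in this assay, compound 2 holds the lower one, with compound 1 as its only neighbour; the step of a 1.7-fold lower number from compound 1 to compound 2 (0.24 log units; within the scatter) lies within the scatter, so the two compounds cannot be told apart on these data. Compound 3, `COc1cc2cc(Oc3ccc(NC(=O)Nc4ccc(Cl)c(Cl)c4)cc3)c(C)nc2cc1OC`, differs from compound 2 in one place: chloro in place of trifluoromethyl on an aromatic carbon. Among the compounds with values here, no measured step bears directly on this exchange; the single step known, a 1.7-fold lower number from compound 1 to compound 2 (0.24 log units; within the scatter), concerns another position and was itself within the scatter. With nothing in the data pointing either way, compound 3 is expected to show no step beyond the scatter from compound 2, a 1.3-fold higher number from compound 2 to compound 3 (0.12 log units; within the scatter). In this assay compound 3 is therefore estimated at 5000 nM, with a range from 2000 nM to 13000 nM.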

Compound 3, concentration for total growth inhibition: 9510 nM
Beside the measured number, compound 3's estimate is 1.9-fold (0.28 log units) below it; measured number inside the range.
By their numbers in this assay, from the lowest: compounds 2, 1 and 3 (each within the scatter of the next, the first and the last beyond it).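

In this assay, going by these compounds alone, chloro in place of trifluoromethyl on this aromatic carbon, ortho to a chloro group, gives a 2.5-fold higher number from compound 2 to compound 3 (0.40 log units; beyond the scatter), the only step so far that passes the scatter, so this position does respond to the exchange, though modestly. The change from 3-(trifluoromethyl)phenyl to 3,4-dichlorophenyl gives a 1.5-fold higher number from compound 1 to compound 3 (0.17 log units; within the scatter), so those two compounds cannot be told apart, and the trifluoromethyl-to-chloro exchange stands out only with the second chloro group in place. The data offer no measured account of why the exchange acts as it does.

As far as these compounds go, whether a methyl, a bromo or a nitrile on this carbon would track with compound 2 or compound 3 stays open. Also open, from the compounds shown here alone, is whether a methoxy or an amine in place of the chloro group ortho to this carbon would alter the step.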